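This account rests on a few compounds, and the source may have more. Where it says the series, first, only, none or still open, it means among the compounds named here.

Compound 3 `COc1cc(-c2nnc3n2NC(c2cccs2)C(C(=O)c2ccc(F)cc2)S3)cc(OC)c1OC` was tested in a functional assay on HepG2 cells (Homo sapiens) for cytotoxicity, read by MTT assay, with a stated time of 48 h (on this read-out higher numbers stand for weaker inhibition and lower numbers for stronger inhibition), where compound 3 gives 54200 nM. Of the two numbers measured, this is the highest. Compound 2 `COc1cc(-c2nnc3n2NC(c2cccs2)C(C(=O)c2ccc(C)cc2)S3)cc(OC)c1OC` differs from compound 3 only at the aromatic carbon that carries a methyl rather than a fluoro, and compound 2 gives 3700 nM. The step of a 15-fold higher number from compound 2 to compound 3 (1.17 log units; beyond the scatter) shows that even a modest exchange on the ring attached to the carbonyl carbon shifts the number strongly. Compound 1 `COc1cc(C(=O)C2Sc3nnc(-c4cc(OC)c(OC)c(OC)c4)n3NC2c2ccco2)cc(OC)c1OC` also carries 3,4,5-trimethoxyphenyl on the carbonyl carbon, though its core differs from that of compound 4 in one other place. Compound 1 gives > 100000 nM, which is a limit of the assay rather than a number (the limit of > 100000 nM in this assay, at which 1 of the 3 values shown sits).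

Compound 4 `COc1cc(C(=O)C2Sc3nnc(-c4cc(OC)c(OC)c(OC)c4)n3NC2c2cccs2)cc(OC)c1OC` follows from compound 3 by this change: 3,4,5-trimethoxyphenyl in place of 4-fluorophenyl on a carbonyl carbon. For the measured compounds named here, no measured step covers exactly this exchange, but the large step from compound 2 to compound 3 shows that this position matters, and compound 1 with the same entering group reached the limit (the limit of > 100000 nM in this assay, at which 1 of the 3 values shown sits). Compound 4 is therefore expected to give a higher number, estimated at 120000 nM with a range from 40000 nM to 350000 nM, and quite possibly only a limit. The expected step is a 2.2-fold higher number from compound 3 to compound 4 (0.35 log units; beyond the scatter).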

Compound 4, half-maximal inhibitory concentration: > 100000 nM
Compound 4 was reported as a limit; the forecaster's own chance of this, stated with the estimate: 60%; the middle value does not contradict the limit.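

With thiophen-2-yl on the saturated ring carbon, 3,4,5-trimethoxyphenyl on the carbonyl carbon also gives no readable number in this assay, so this outcome is not confined to compound 1 with its furan-2-yl. The exchange for 4-fluorophenyl gives an at least 1.8-fold higher number from compound 3 to compound 4 (0.26 log units; that floor lies within the scatter), which alone shows little, while the exchange for 4-methylphenyl gives an at least 27-fold higher number from compound 2 to compound 4 (1.43 log units; beyond the scatter), a clear loss against the best-measured compound of this set. Compound 1 and compound 4 are both limits and not numbers, so the step between them cannot be read: the limit of > 100000 nM in this assay, at which 2 of the 4 values shown sit.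

From the compounds shown here alone, how far compound 4 lies past its limit stays open. So does what a phenyl carrying a single methoxy group, or an amine on that phenyl ring, would give on the carbonyl carbon, which would show whether one methoxy group is enough for this outcome.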